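This account rests on a few compounds, and the source may have more. Where it says the series, first, only, none or still open, it means among the compounds named here.

Compound 1 `CCN(CC)CC[n+]1c(SCC(=O)NCCCN)[nH]c2c(C)nc(N(CC)CC)nc21` — in an ADME assay on CEM174 cells (Homo sapiens) for cytotoxicity (on this read-out lower numbers stand for higher toxicity in this test and higher numbers for lower toxicity in this test), compound 1 gives > 100 uM, which is a limit of the assay and not a number.
Compound 2 `CCN(CC)c1nc(C)c2[nH]c(SCC(=O)NCCCN)[n+](CCCN(C)C)c2n1` — in this assay compound 2 gives > 100 uM, likewise a limit and not a number.

Compound 2 thus stands at the boundary of what this assay reports, and it does not stand there alone: the limit of > 100 uM in this assay, at which 2 of the 2 values shown sit. For the measured compounds named here, the single measured step, a step that the two limits leave unreadable from compound 1 to compound 2, exchanges (dimethylamino)methyl for diethylamino on a saturated chain carbon, two bonds along the chain from an aromatic nitrogen, and its size cannot be read from two limits.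

Compound 3 `CCN(CC)c1nc(C)c2[nH]c(SCC(=O)NCCCNC(=N)N)[n+](CCCN(C)C)c2n1` is the compound still to be measured. It differs from compound 2 by a group of 3 heavy atoms (1 carbon, 2 nitrogen; no ring) in place of a hydrogen atom, on an amine nitrogen. Going by the values given here, no measured step touches this amine nitrogen, and the one step that exists gives neither a size nor a direction, so there is no ground on which to expect a move beyond the scatter. Compound 3 is therefore expected to show a step of a number no higher from compound 2 to compound 3 (the limit leaves the size open) in this assay. The estimate for compound 3 in this assay is 100 uM, with a range from 50 uM to 200 uM, and it is expected that the assay will again report only a limit.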

Compound 3, half-maximal toxic concentration: > 100 uM
Compound 3 was reported as a limit; the forecaster's own chance of this, stated with the estimate: 80%; the middle value lies on the limit itself.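

No new step can be read from compound 2 to compound 3, as compound 3, like compound 2, is reported in this assay only as a limit and not as a number: the limit of > 100 uM in this assay, at which 3 of the 3 values shown sit. The compounds shown leave open how far each lies from that limit, and whether either exchange changes the half-maximal toxic concentration at all.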